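This account rests on a few compounds, and the source may have more. Where it says the series, first, only, none or still open, it means among the compounds named here.

Measured compounds:
- compound 1 `N=C(S)CCCCCCN1N=C(c2ccccc2)CCC1=O`: in a functional assay on the whole organism (stomach) for inhibition, with Rattus norvegicus as the target, at a dose of 100 mg/kg by the intraduodenal route (a lower number here means less inhibition, a higher number more inhibition at the dose given (going by the name of the read-out)), compound 1 gives 68.3%
- compound 2 `Cc1ccc(=O)n(CCCCCCC(=N)S)n1`: in this assay compound 2 gives 29.5%
- compound 3 `N=C(S)CCCCCCn1nc(-c2ccccc2)ccc1=O`: in this assay compound 3 gives 33.9%

Compound 3 stands second highest of the three numbers. Its nearest neighbour is compound 2, within the scatter; its furthest is compound 1, beyond the scatter. Going by the values given here, the one step between measured compounds that differ in one place, a number 4.4 percentage points higher from compound 2 to compound 3 (within the scatter), is within the scatter.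

Compound 4 `N=C(S)CCCCn1nc(-c2ccccc2)ccc1=O` is not yet measured. The change from compound 3 to compound 4 is a group of 3 heavy atoms (1 carbon, 1 nitrogen, 1 sulfur; no ring) in place of a group of 5 heavy atoms (3 carbon, 1 nitrogen, 1 sulfur; no ring), on a saturated chain carbon, four bonds along the chain from an aromatic nitrogen. Among the compounds with values here, no measured step touches this chain: the only step on record, a number 4.4 percentage points higher from compound 2 to compound 3 (within the scatter), concerns the group on the aromatic carbon, not the chain, so it gives no bearing on direction or size here. Without a relevant precedent the working expectation is a step of no particular direction beyond the scatter, a number 0.1 percentage points higher from compound 3 to compound 4 (within the scatter), with a wide range. Compound 4 is therefore expected to give about 34% in this assay, between 14% and 56%.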

Compound 4, a percentage reported as inhibition, in the whole organism at one dose (the size of the read-out at that dose, not a potency): 33.8%
Compound 4: the middle estimate sits 0.2 percentage points above what was measured, and the stated range covers the measured number.
By their numbers in this assay, from the lowest: compounds 2, 4 and 3 (each within the scatter of the next); then compound 1.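

In this assay, the group of 3 heavy atoms in place of the group of 5 heavy atoms gives a number 0.1 percentage points lower from compound 3 to compound 4 (within the scatter) on the shared core, so this shortening of the chain brings no readable shift at this position, on a saturated chain carbon, four bonds along the chain from an aromatic nitrogen. Going by these compounds alone, this is the first reading on the chain itself, as the earlier step concerned only the group on the aromatic carbon. Nothing at hand offers an explanation for this flat result.

From the compounds shown here alone, it remains open whether a longer chain, or an amine or a carboxylic acid on this chain, would move the number on this core. Also open, going by these compounds, is whether the same shortening would matter on the core of compound 1, which gives 68.3% in this assay and stands apart from the other three.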